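The compounds below may be only part of what the source reports. "The series", "measured", "known", "first", "only" and "open" are said of these compounds alone.

Among the measured compounds shown here, in a functional assay (aorta) with Rattus norvegicus as the target (a higher number here means a weaker inhibitor, a lower number a stronger inhibitor), two compounds have numbers so far: compound 1 `CCCCc1cn2ccccc2c1S(=O)(=O)c1ccc(OCCCN(CCC)CCC)cc1` gives 570 nM, and compound 2 `CCCN(CCC)CCCOc1ccc(S(=O)(=O)c2c(C(C)C)cn3ccccc23)cc1` gives 102 nM, the lower of the two. Compound 3 `CCCN(CCC)CCCOc1ccc(S(=O)(=O)c2c(CC)cn3ccccc23)cc1` differs from compound 2 by one change: hydrogen in place of methyl on a saturated chain carbon bound to an aromatic carbon and a saturated chain carbon, which reads as isopropyl to ethyl. For the measured compounds named here, only one measured step bears on this, isopropyl in place of butyl on an aromatic carbon: a 5.6-fold lower number from compound 1 to compound 2 (0.75 log units; beyond the scatter). Like butyl, ethyl is unbranched, so a modest rise in the number is expected in this assay, probably smaller than that step, although a single step is thin evidence. The expected change is a 2.0-fold higher number from compound 2 to compound 3 (0.29 log units; within the scatter). For compound 3 the estimate is 200 nM, with an expected range of 80 nM to 500 nM.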

Compound 3, half-maximal inhibitory concentration: 150 nM
Compound 3: the middle estimate sits 1.3-fold (0.12 log units) above what was measured; measured number inside the range.
By their numbers in this assay, from the lowest: compounds 2 and 3 (each within the scatter of the next); then compound 1.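

In this assay, ethyl and isopropyl on this aromatic carbon cannot be told apart (a 1.5-fold higher number from compound 2 to compound 3 (0.17 log units; within the scatter)), so the branch of isopropyl is not needed for a number in the range of compound 2. The shortening of butyl to ethyl is a step beyond the scatter (a 3.8-fold lower number from compound 1 to compound 3 (0.58 log units; beyond the scatter)), which sets compound 1 apart from both others and recasts the earlier contrast as butyl against the two smaller groups, not as branched against unbranched. No measurement is at hand to explain why butyl stands apart.

As far as these compounds go, whether a propyl chain at this place reads with ethyl or with butyl stays open. Also open, from the compounds shown here alone, is how a methyl, cyclopropyl or phenyl group would read on this aromatic carbon.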